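Adding a Nitrile to the Benzyl Ring of Compound 1

The source may hold more compounds than are shown below. What is called first, only, known or untested is meant among the compounds shown, and "the series" means these compounds.

Three compounds share one core. Compound 1 `COc1cccc(CNCCCNc2ccnc3cc(Cc4ccccc4)ccc23)c1O`, compound 2 `Fc1ccc(Cc2ccc3c(NCCCNCc4ccco4)ccnc3c2)c(Cl)c1` and compound 3 `Cc1cc(C)cc(Cc2ccc3c(NCCCNCc4ccco4)ccnc3c2)c1` each carry a benzyl group on that core. In a physicochemical assay for solubility, with a stated time of 18 h, at pH 7.4 (on this read-out higher numbers stand for higher solubility and lower numbers for lower solubility), compound 1 gives 4200 nM, compound 2 gives 4200 nM and compound 3 gives 4200 nM, so compound 1 stands level with both. Compound 4 `COc1cccc(CNCCCNc2ccnc3cc(Cc4ccc(C#N)cc4)ccc23)c1O` differs from compound 1 by cyano in place of hydrogen on an aromatic carbon, on that same benzyl ring. Going by the values given here, only one measured step alters this ring, and because no change at the digits printed from compound 2 to compound 3 (within the scatter) left the read-out unmoved, a nitrile on the ring is expected to produce no step beyond the scatter either. The estimate for compound 4 in this assay is therefore 4200 nM, within 2100 nM to 8400 nM, an expected step of no change at the digits printed from compound 1 to compound 4 (within the scatter).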

Compound 4, solubility: 4200 nM
Compound 4: the middle estimate sits on the measured number at the digits printed; low and high end bracket the measured number.
By their numbers in this assay, from the lowest: compounds 1, 2, 3 and 4 (each within the scatter of the next).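

In this assay, going from benzyl to 4-cyanobenzyl gives no change at the digits printed from compound 1 to compound 4 (within the scatter), so this place, para to a large group, now has a measured change on the core of compound 1 itself. The earlier step swapped one substituted ring for another on compounds that differ from compound 1 elsewhere, whereas this one adds a single cyano group to an unsubstituted ring. Nothing measured here gives a reason for this outcome. From the compounds shown here alone, whether an amine or a carboxylic acid at this same place would also leave the read-out within the scatter remains open.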